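Replacing the Benzoyl Group: Tolerance of Compound 4

The source may hold more compounds than are shown below. What is called first, only, known or untested is meant among the compounds shown, and "the series" means these compounds.

Compound 1 `Cc1cn([C@@H]2O[C@H](CO[Si](C)(C)C(C)(C)C)[C@@]3(OS(=O)(=O)C=C3NC(=O)c3ccccc3)[C@H]2O[Si](C)(C)C(C)(C)C)c(=O)n(C)c1=O`: 4900 nM
Compound 2 `Cc1cn([C@@H]2O[C@H](CO[Si](C)(C)C(C)(C)C)[C@@]3(OS(=O)(=O)C=C3NCCC(N)=O)[C@H]2O[Si](C)(C)C(C)(C)C)c(=O)n(C)c1=O`: 20000 nM
Compound 3 `COC(=O)CNC1=CS(=O)(=O)O[C@@]12[C@@H](CO[Si](C)(C)C(C)(C)C)O[C@@H](n1cc(C)c(=O)n(C)c1=O)[C@@H]2O[Si](C)(C)C(C)(C)C`: 105000 nM

The three measured compounds share one core and differ only in the group on the amine nitrogen. In a functional assay on MT4 cells (Homo sapiens) (a higher number here means that more compound is tolerated, a lower number that less compound is tolerated), compound 1 gives the lowest of the three numbers, so it is the compound of which least is tolerated. Its nearest neighbour is compound 2, reached by a 4.1-fold higher number from compound 1 to compound 2 (0.61 log units; beyond the scatter); the furthest is compound 3, reached by a 21-fold higher number from compound 1 to compound 3 (1.33 log units; beyond the scatter). Between those two, a 5.3-fold higher number from compound 2 to compound 3 (0.72 log units; beyond the scatter).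

Compound 4 `Cc1cn([C@@H]2O[C@H](CO[Si](C)(C)C(C)(C)C)[C@@]3(OS(=O)(=O)C=C3NCC(=O)C(=O)N3CCC3)[C@H]2O[Si](C)(C)C(C)(C)C)c(=O)n(C)c1=O` has not yet been measured. It differs from compound 1 in one place: (((azetidin-1-yl)carbonyl)carbonyl)methyl in place of benzoyl on an amine nitrogen. Both measured steps away from compound 1 bear on this change, since each of them also puts a chain in place of the benzoyl group, and both raised the number beyond the scatter, one modestly and one by a large margin. A rise in this assay is therefore expected for compound 4 as well, most likely of modest size, a 5.1-fold higher number from compound 1 to compound 4 (0.71 log units; beyond the scatter). The estimate for compound 4 is 25000 nM, with a range from 8000 nM to 80000 nM.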

Compound 4, half-maximal cytotoxic concentration: 17400 nM
Beside the measured number, compound 4's estimate is 1.4-fold (0.16 log units) above it; low and high end bracket the measured number.
By their numbers in this assay, from the lowest: compound 1; then compounds 4 and 2 (each within the scatter of the next); then compound 3.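

With compound 4, a third group on the amine nitrogen in place of benzoyl raises the number in this assay, a 3.6-fold higher number from compound 1 to compound 4 (0.55 log units; beyond the scatter), and this time the entering group carries a four-membered non-aromatic ring, so a ring in that group does not keep the number near that of compound 1. The chain of compound 4 does not separate from the carbamoylethyl chain of compound 2, a 1.1-fold lower number from compound 2 to compound 4 (0.06 log units; within the scatter), whereas the ester chain of compound 3 remains apart, with a 6.0-fold lower number from compound 3 to compound 4 (0.78 log units; beyond the scatter), so compound 3 alone carries the highest number in the series. No measurement shown here accounts for these differences in tolerance.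

The compounds shown leave open whether the rise from compound 1 goes with the loss of the aromatic ring or with the loss of the carbonyl bound directly to the amine nitrogen, which an acetyl or a benzyl group at this place would help to separate. They also leave open whether the high number of compound 3 depends on its methyl ester, a question that a carboxylic acid or an ethyl ester on the same chain would address.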